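The source may report more compounds than this note shows. Statements on the series, on what has been measured and on what is new or still open speak of the compounds shown alone.

Measured in a functional assay on A549 cells (Homo sapiens) for antiproliferative activity, read by MTT assay, with a stated time of 48 h; a lower number here means a stronger inhibitor, a higher number a weaker inhibitor:
- compound 1 `C/C(=C\CC/C(C)=C/CC[C@@H]1[C@@]2(C)CCC(=O)C(C)(C)[C@H]2CC[C@@]1(C)O)CC/C=C(\C)C(=O)OCc1cn(-c2cccc(Cl)c2)nn1`: 147000 nM
- compound 2 `C/C(=C\CC/C(C)=C/CC[C@@H]1[C@@]2(C)CCC(=O)C(C)(C)[C@H]2CC[C@@]1(C)O)CC/C=C(\C)C(=O)OCc1cn(-c2cccc(F)c2)nn1`: 124000 nM

Going by the values given here, with 124000 nM, compound 2 stands level with compound 1, the only other measured compound, and neither can be ranked above the other. Among the compounds with values here, the single measured step, a 1.2-fold lower number from compound 1 to compound 2 (0.07 log units; within the scatter), is fluoro in place of chloro on an aromatic carbon.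

The next compound is compound 3 `C/C(=C\CC/C(C)=C/CC[C@@H]1[C@@]2(C)CCC(=O)C(C)(C)[C@H]2CC[C@@]1(C)O)CC/C=C(\C)C(=O)OCc1cn(-c2ccccc2Cl)nn1`, and the change from its predecessor is 2-chlorophenyl in place of 3-fluorophenyl on an aromatic nitrogen. In words, this is 2-chlorophenyl in place of 3-fluorophenyl on an aromatic nitrogen. The measured step bears on the exchange of halogen, read in reverse, and it offers no sign of a large effect. Within the data shown here, no measured compound carries a 2-chlorophenyl group, so that part of the change remains untested. On the evidence of the step of a 1.2-fold lower number from compound 1 to compound 2 (0.07 log units; within the scatter), a change no larger than the scatter is expected in this assay, with no direction favoured.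

The estimated step is a 1.0-fold higher number from compound 2 to compound 3 (0.02 log units; within the scatter). For compound 3 the expected value is 130000 nM, with an estimated range of 70000 nM to 230000 nM.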

Compound 3, half-maximal inhibitory concentration: > 150000 nM
Compound 3: no number, only a limit (the forecaster's own chance of this, stated with the estimate: 15%); middle value at least 1.1-fold (0.06 log units) from the limit.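

In this assay, compound 3 gives no number, only a limit: > 150000 nM. Going by these compounds alone, this is the first view of the 2-chlorophenyl group on the aromatic nitrogen, and the comparison with compound 1 is the first in which the chlorine changes place on the phenyl ring rather than being exchanged for another halogen, yet the readable steps are only floors: an at least 1.2-fold higher number from compound 2 to compound 3 (0.08 log units; that floor lies within the scatter), and an at least 1.0-fold higher number from compound 1 to compound 3 (0.00 log units; that floor lies within the scatter). The true size of either step therefore stays unknown, and the three compounds cannot be put in order, since the only result for this change is a limit: the limit of > 150000 nM in this assay, at which 1 of the 3 values shown sits.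

The compounds shown leave open how far the value of compound 3 lies past its limit, and so whether moving the chlorine matters at all in this assay. They also leave open whether a plain phenyl, a methoxy group or an amine on that phenyl ring, or a carboxylic acid in place of the ester, would shift the values of this series by more than the scatter.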